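The source may report more compounds than this note shows. Statements on the series, on what has been measured and on what is new or still open speak of the compounds shown alone.

Working notes, series of benzoxazole sulfonamides.

Measured so far:
compound 1 `COc1ccccc1S(=O)(=O)Nc1ccc2oc(-c3ccccc3)nc2c1` — > 63000 nM
compound 2 `O=S(=O)(Nc1ccc2oc(-c3ccccc3)nc2c1)c1ccc(O)cc1` — > 63000 nM
compound 3 `O=S(=O)(Nc1ccc(-c2nc3ccccc3o2)cc1)c1ccc(O)cc1` — > 63000 nM

All three values come from an assay on isolated protein for inhibition of malate dehydrogenase, mitochondrial (Sus scrofa), with stated times of 45 min and 30 min; a lower number here means a stronger inhibitor, a higher number a weaker inhibitor. For compound 1 the value > 63000 nM is a limit of the assay and not a number. For compound 2 the value > 63000 nM is likewise a limit. For compound 3 the value > 63000 nM is again a limit.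

Compound 2 and compound 1 differ in one place: 2-methoxyphenyl in place of 4-hydroxyphenyl on a sulfonyl sulfur. The step that the two limits leave unreadable from compound 2 to compound 1 cannot be sized, because the limit of > 63000 nM in this assay, at which 3 of the 3 values shown sit, leaves both ends of it as limits. Compound 2 and compound 3 share the same atoms joined differently; the difference between the two cores is not broken down here.

Not yet measured is compound 4 `COc1ccccc1S(=O)(=O)Nc1ccc(-c2nc3ccccc3o2)cc1`. It stands to compound 3 as compound 1 stands to compound 2: 2-methoxyphenyl in place of 4-hydroxyphenyl on a sulfonyl sulfur, at the same place, so this is the same change, made twice among the compounds shown. Since the earlier instance of the change and all three measured values sit at the limit of this assay, the expectation for compound 4 rests only on that: the step that the limit leaves unreadable from compound 3 to compound 4 is expected to be unreadable in the same way, with compound 4 again expected to return a limit rather than a number. The estimated value for compound 4 in this assay is 100000 nM, expected to fall between 50000 nM and 400000 nM.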

Compound 4, half-maximal inhibitory concentration: > 63000 nM
Compound 4: only a limit was reported; the forecaster's own chance of this, stated with the estimate: 85%; the middle value does not contradict the limit.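

In this assay compound 4 gives > 63000 nM, which is a limit and not a number. No step can be read from compound 3 to compound 4, nor any new step among the compounds shown, because both ends are limits: the limit of > 63000 nM in this assay, at which 4 of the 4 values shown sit. The compounds shown leave open how large the change from 4-hydroxyphenyl to 2-methoxyphenyl would be in a compound returning a number.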